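This account rests on a few compounds, and the source may have more. Where it says the series, first, only, none or still open, it means among the compounds named here.

Working notes on the series. In a functional assay on B16-F10 cells (Mus musculus) for antiproliferative activity, read by MTT assay, with a stated time of 48 h (on this read-out lower numbers stand for stronger inhibition and higher numbers for weaker inhibition), compound 1 (`COc1ccc(/C=C/c2cc(OC)cc(OC)c2/C=C/C(=O)c2cccc(Br)c2)cc1`) gives 5.1 ug/mL, compound 2 (`CCCCCCOc1ccc(C(=O)/C=C/c2c(/C=C/c3ccc(OC)cc3)cc(OC)cc2OC)cc1`) gives 10.4 ug/mL and compound 3 (`COc1ccc(/C=C/c2cc(OC)cc(OC)c2/C=C/C(=O)c2ccc(C(F)(F)F)cc2)cc1`) gives 4.3 ug/mL. Compound 3 cannot be told apart from compound 1, and only compound 2 stands clearly apart from it. Compound 4 (`COc1ccc(/C=C/c2cc(OC)cc(OC)c2/C=C/C(=O)c2ccc(Cl)cc2)cc1`) carries chloro in place of trifluoromethyl on an aromatic carbon. Among the compounds with values here, two measured steps bear on this change. The exchange of substituted phenyl groups gives a 1.2-fold lower number from compound 1 to compound 3 (0.07 log units; within the scatter), and the larger exchange of hexyloxy for trifluoromethyl gives only a 2.4-fold lower number from compound 2 to compound 3 (0.38 log units; beyond the scatter). No shift beyond the scatter is therefore expected in this assay. The expected step is a 1.1-fold higher number from compound 3 to compound 4 (0.05 log units; within the scatter). For compound 4 the estimated value is 4.8 ug/mL, with an expected range of 2.6 ug/mL to 9 ug/mL.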

Compound 4, half-maximal inhibitory concentration: 4.9 ug/mL
The estimate for compound 4 lay 1.0-fold (0.01 log units) below the measured number, and the stated range covers the measured number.
By their numbers in this assay, from the lowest: compounds 3, 4 and 1 (each within the scatter of the next); then compound 2.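

In this assay, the step of a 1.1-fold higher number from compound 3 to compound 4 (0.06 log units; within the scatter) shows that, para to a large group, chloro with its single heavy atom cannot be told apart from trifluoromethyl with its four. The step of a 1.0-fold lower number from compound 1 to compound 4 (0.02 log units; within the scatter) places the 4-chlorophenyl compound level with the 3-bromophenyl compound, while the step of a 2.1-fold lower number from compound 2 to compound 4 (0.33 log units; beyond the scatter) is beyond the scatter and keeps the hexyloxy compound apart. No supporting evidence accounts for these steps. The compounds shown leave open whether an amine or a carboxylic acid at this position would shift the number beyond the scatter.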